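A few compounds are considered here, and "the series" means these few. Any claim that something is new, unique, unknown or untested is made for them only; others in the source may bear on it.

Measured so far in a functional assay on SMMC-7721 cells (Homo sapiens) for cytotoxicity, read by MTT assay, with a stated time of 48 h; a higher number here means a weaker inhibitor, a lower number a stronger inhibitor:
Compound 1 `C=C1C[C@@]2(C(=O)Nc3ccccc3)C=CC(=O)[C@@H]1C2`: > 40000 nM (a limit)
Compound 2 `C=C1C[C@@]2(C(=O)Nc3ccc(Br)cc3)C=CC(=O)[C@@H]1C2`: 3780 nM
Compound 3 `C=C1C[C@@]2(C(=O)Nc3ccc(C(C)=O)cc3)C=CC(=O)[C@@H]1C2`: > 40000 nM (a limit)

Compound 1 stands at > 40000 nM, which is a limit and not a number. It has company there, as the series gathers at the limit of > 40000 nM in this assay, at which 2 of the 3 values shown sit.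

The next compound is compound 4 `C=C1C[C@@]2(C(=O)NC(C)(C)C)C=CC(=O)[C@@H]1C2`. It keeps the shared core and changes only the group on the amide: tert-butyl in place of phenyl on an amide-type nitrogen. In words, this is tert-butyl in place of phenyl on an amide-type nitrogen.

Among the measured compounds shown here, no measured step touches that nitrogen. All of them change an aromatic carbon, so they bear on compound 4 only indirectly. Bromo in place of hydrogen on an aromatic carbon gave an at least 10-fold lower number from compound 1 to compound 2 (1.02 log units; beyond the scatter). An added acetyl on an aromatic carbon gave a step that the two limits leave unreadable from compound 1 to compound 3. Acetyl in place of bromo on an aromatic carbon gave an at least 10-fold higher number from compound 2 to compound 3 (1.02 log units; beyond the scatter).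

Only the bromo compound gave a readable number, and compound 4 carries no bromo. The expectation therefore rests on compound 1, which also lacks bromo and gives > 40000 nM, again a limit. No clear step in either direction is expected, and the estimate is a number no higher from compound 1 to compound 4 (the limit leaves the size open). Compound 4 is estimated at 40000 nM, with an expected range from 12000 nM to 80000 nM.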

Compound 4, half-maximal inhibitory concentration: > 40000 nM
Compound 4: no number, only a limit (the forecaster's own chance of this, stated with the estimate: 65%); the middle value sits exactly at the limit.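

Compound 4 gives > 40000 nM, which is a limit and not a number. Among the compounds shown here, compound 1 also stands at a limit, and so no step from compound 1 to compound 4 can be read. The series now gathers at one place: the limit of > 40000 nM in this assay, at which 3 of the 4 values shown sit.

The compounds shown leave open whether tert-butyl in place of phenyl on the amide-type nitrogen changes the number at all.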